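Trimming the piperazine substituent of a dithiocarbamate benzamide

The compounds below may be only part of what the source reports. "The series", "measured", "known", "first", "only" and "open" are said of these compounds alone.

Compound 1 `Nc1ccccc1NC(=O)c1ccc(CSC(=S)N2CCN(Cc3ccccn3)CC2)cc1` carries a (pyridin-2-yl)methyl group on the piperazine nitrogen of the shared core. In a functional assay on MGC-803 cells (Homo sapiens) for antiproliferative activity, read by CCK-8 assay, with a stated time of 72 h, tested at 8 uM (a higher number here means a stronger effect of the compound at the concentration tested, a lower number a weaker effect), compound 1 gives 65.2%, the second highest of the three numbers measured. Compound 2 `Nc1ccccc1NC(=O)c1ccc(CSC(=S)N2CCN(c3ccc(F)cc3)CC2)cc1` gives 48.7%, and the step of a number 16.5 percentage points lower from compound 1 to compound 2 (beyond the scatter) is beyond the scatter. Compound 3 `Nc1ccccc1NC(=O)c1ccc(CSC(=S)N2CCN(c3cnccn3)CC2)cc1` gives 80.5%, with the step of a number 15.3 percentage points higher from compound 1 to compound 3 (beyond the scatter), also beyond the scatter, while a number 31.8 percentage points higher from compound 2 to compound 3 (beyond the scatter) is the largest step in the set.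

Compound 4 `CN1CCN(C(=S)SCc2ccc(C(=O)Nc3ccccc3N)cc2)CC1` differs from compound 1 by hydrogen in place of pyridin-2-yl on a saturated chain carbon bound to an amine nitrogen in a ring. The measured steps swap one ring for another on the amine nitrogen in the ring; none removes the ring entirely, so they bear only loosely on this change. Both show that this position moves the read-out by modest amounts in either direction. Compound 4 is therefore expected to lose some effect, a step of a number 15.2 percentage points lower from compound 1 to compound 4 (beyond the scatter). Compound 4 is estimated at 50%, within the range 30% to 68%.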

Compound 4, a percentage reported as inhibition, at one concentration (the size of the read-out at that concentration, not a potency): 84.4%
Compound 4: middle estimate off by 34.4 percentage points, on the low side; the whole stated range lies below it.
By their numbers in this assay, from the lowest: compound 2; then compound 1; then compounds 3 and 4 (each within the scatter of the next).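

In this assay, taking the pyridin-2-yl off the saturated chain carbon bound to the amine nitrogen in the ring costs no effect but gains it (a number 19.2 percentage points higher from compound 1 to compound 4 (beyond the scatter)), which the ring-for-ring swaps could not show: no ring is needed at this position for this read-out. The small methyl stands level with the pyrazin-2-yl (a number 3.9 percentage points higher from compound 3 to compound 4 (within the scatter)) and clear of the 4-fluorophenyl (a number 35.7 percentage points higher from compound 2 to compound 4 (beyond the scatter)), so a group with no ring at all matches the best ring tested here. No measurement at hand explains this result.

From the compounds shown here alone, it remains open whether a longer chain such as ethyl or propyl, or a hydroxyethyl group, on that nitrogen would hold this level. These read-outs, each taken at one concentration, also leave open how compound 3 and compound 4 compare in potency.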